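Amide aryl swaps on a weakly active shared core

A few compounds are considered here, and "the series" means these few. Any claim that something is new, unique, unknown or untested is made for them only; others in the source may bear on it.

Measured so far:
compound 1, `O=C(Nc1ccc(Cl)c(-c2nnc3c(Cl)cccn23)c1)c1ccccc1Cl`: > 100000 nM
compound 2, `Cc1cc(Cl)ccc1C(=O)Nc1ccc(Cl)c(-c2nnc3c(Cl)cccn23)c1`: 34300 nM

Compound 1 sits at the edge of what a functional assay on MDA-MB-468 cells (Homo sapiens) for antiproliferative activity, read by MTT assay, with a stated time of 72 h (on this read-out lower numbers stand for stronger inhibition and higher numbers for weaker inhibition), can report: the value > 100000 nM is a limit of the assay, not a number (the limit of > 100000 nM in this assay, at which 1 of the 2 values shown sits). In this assay compound 2 gives 34300 nM, which is a real number. Among the measured compounds shown here, the single measured step is an at least 2.9-fold lower number from compound 1 to compound 2 (0.46 log units; beyond the scatter), and since it starts from a limit it is only a lower bound on the change.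

Compound 3, `O=C(Nc1ccc(Cl)c(-c2nnc3c(Cl)cccn23)c1)c1cccnc1Cl`, has not been measured. It differs from compound 1 by 2-chloropyridin-3-yl in place of 2-chlorophenyl on a carbonyl carbon. For the measured compounds named here, no measured step shares this change; the step between compound 1 and compound 2 replaces the same ring but with a different group, so it bears on compound 3 only in showing that altering this ring can move the number. On that basis no step beyond the scatter is expected, a step that the limit leaves unreadable from compound 1 to compound 3, and compound 3 is estimated at 150000 nM with a range of 30000 nM to 400000 nM, with a limit rather than a number being the likelier outcome.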

Compound 3, half-maximal inhibitory concentration: > 100000 nM
Compound 3 ended at the assay's limit; the forecaster's own chance of this, stated with the estimate: 70%; the middle value lies beyond the limit too.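

Replacing 2-chlorophenyl with 2-chloropyridin-3-yl on a carbonyl carbon leaves the series with a second compound at the edge of what this assay can report: the limit of > 100000 nM in this assay, at which 2 of the 3 values shown sit. The step between compound 1 and compound 3 cannot be read, so the swap of a carbon-only ring for a ring with 1 hetero atom and 1 hydrogen-bond acceptor may have moved the true value in either direction, or not at all, without this read-out showing it. Among the compounds shown here, the one readable new comparison is an at least 2.9-fold higher number from compound 2 to compound 3 (0.46 log units; beyond the scatter), and it is only a lower bound. Of the three groups shown at this place, only 4-chloro-2-methylphenyl gives a real number, as compound 2 gives 34300 nM.

Open is which part of 4-chloro-2-methylphenyl carries that real number, the methyl or the chlorine, since the compounds shown change both together. Also open, on these data alone, is whether a methoxy group or an amine on the ring at this place would bring the value further inside the range of this assay, and whether any change here can lift the shared core beyond weak activity.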